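Swapping One Benzyl Group Without a Starting Number

The source may report more compounds than this note shows. Statements on the series, on what has been measured and on what is new or still open speak of the compounds shown alone.

Compound 1 (`COc1ccc(/C=C2\CN(C(=S)SCc3cn(Cc4ccccc4F)nn3)C/C(=C\c3ccc(OC)cc3)C2=O)cc1`) gives "not determined" (no result reported)
Compound 2 (`COc1ccc(/C=C2\CN(Cc3cn(Cc4cccc(Cl)c4)nn3)C/C(=C\c3ccc(OC)cc3)C2=O)cc1`) gives > 100000 nM

In an ADME assay on HEK293 cells (Homo sapiens) for cytotoxicity, read by MTT assay, with a stated time of 24 h (a lower number here means a stronger inhibitor, a higher number a weaker inhibitor), compound 1 has no number at all, and its entry reads "not determined" (no result reported) and nothing more. Compound 2 gives > 100000 nM as its result, and this is a limit of the assay, not a number. Compound 3 (`COc1ccc(/C=C2\CN(C(=S)SCc3cn(Cc4cccc(Cl)c4)nn3)C/C(=C\c3ccc(OC)cc3)C2=O)cc1`) still awaits its measurement. The change from the structure of compound 1 is a single swap: 3-chlorophenyl in place of 2-fluorophenyl on a saturated chain carbon bound to an aromatic nitrogen. In words, 3-chlorophenyl stands in place of 2-fluorophenyl on a saturated chain carbon bound to an aromatic nitrogen, which turns a 2-fluorobenzyl into a 3-chlorobenzyl. Within the data shown here, compound 1 offers no number to start from, so no step can be sized from it, and in this assay no step beyond the usual scatter is expected from this swap. The expectation therefore leans on compound 2 at > 100000 nM, again a limit. The result may well come back as a limit too. If a number is obtained, compound 3 is estimated at 80000 nM, with an expected range from 25000 nM to 100000 nM.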

Compound 3, half-maximal inhibitory concentration: > 100000 nM
Compound 3: no number, only a limit (the forecaster's own chance of this, stated with the estimate: 55%); middle value at least 1.2-fold (0.09 log units) away from the limit.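

In this assay compound 3 gives > 100000 nM, which is a limit of the assay and not a number. Among these compounds, compound 1 offers no number to set beside it, so no step between compound 1 and compound 3 can be read. The compounds shown leave open whether changing 2-fluorobenzyl to 3-chlorobenzyl alters the result at all, and the only firm reading is: the limit of > 100000 nM in this assay, at which 2 of the 3 values shown sit.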